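A few compounds are considered here, and "the series" means these few. Any claim that something is new, unique, unknown or untested is made for them only; others in the source may bear on it.

Compounds measured so far and the one still to come:
- compound 1 `CC(=O)Nc1c(C)c(C)c2c(c1C)CC(C)(C)O2`: > 100 mg/kg
- compound 2 `CNc1c(C)c(C)c2c(c1C)CC(C)(C)O2`: 16.6 mg/kg
- compound 3 `CCNc1c(C)c(C)c2c(c1C)CC(C)(C)O2`: not yet measured

The test used here is a functional assay on the whole organism with Mus musculus as the target; a lower number here means that less compound is needed, a higher number that more compound is needed for the effect. Compound 1 gives > 100 mg/kg, which is a limit of the assay and not a number. Among the measured compounds shown here, compound 2, at 16.6 mg/kg, therefore holds the only true number so far, so it can be compared with compound 1 in one direction only.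

Compound 3 extends the methylamino group of compound 2 to an ethylamino group: methyl in place of hydrogen on a saturated chain carbon bound to a nitrogen on an aromatic ring. In words, a methyl stands in place of a hydrogen on a saturated chain carbon bound to a nitrogen on an aromatic ring.

For the measured compounds named here, only one measured step bears on this: an at least 6.0-fold lower number from compound 1 to compound 2 (0.77 log units; beyond the scatter). It swaps acetyl for methyl on that same nitrogen, which is a different kind of change, so it shows that this nitrogen's substituent can matter but gives no size for adding a methyl to the chain. In this assay, no step beyond the scatter is therefore expected, and neither direction is favoured.

The expected step is a 1.1-fold lower number from compound 2 to compound 3 (0.04 log units; within the scatter). For compound 3 the estimated value is 15 mg/kg, with an expected range from 5 mg/kg to 50 mg/kg.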

Compound 3, dose for 50% inhibition: 38.9 mg/kg
Compound 3: middle estimate off by 2.6-fold (0.41 log units), on the low side; low and high end bracket the measured number.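

In this assay, adding a single methyl to the saturated chain carbon bound to the nitrogen on the aromatic ring gives a 2.3-fold higher number from compound 2 to compound 3 (0.37 log units; beyond the scatter). The earlier step showed only that swapping acetyl for methyl on this nitrogen can matter, whereas the change from methylamino to ethylamino now has a direction and size of its own: even this small extension moves the number toward needing more compound. Ethyl in place of acetyl still gives an at least 2.5-fold lower number from compound 1 to compound 3 (0.41 log units; beyond the scatter), so compound 3 stays clearly on the better side of compound 1, but the true size of this step remains unknown because the result for compound 1 is a limit of the assay and not a number: the limit of > 100 mg/kg in this assay, at which 1 of the 3 values shown sits.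

The compounds shown leave open whether a longer chain such as propyl, or a branched group such as isopropyl, would raise the number further, as one step does not make a trend. They also leave open how the primary amine, with hydrogen in place of the methyl of compound 2, would compare with these alkyl groups.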